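Removing a Fluoro Group from a Cytotoxic Quinazoline-Type Compound

This account rests on a few compounds, and the source may have more. Where it says the series, first, only, none or still open, it means among the compounds named here.

Compound 1, `CN(C)CCCNc1nc(NCc2ccco2)c2ccccc2n1`: "not determined" (no result reported).
Compound 2, `CCN(CC)CCNc1nc(NCc2ccco2)c2cc(F)ccc2n1`: 26.6%.

In a functional assay on DU-145 cells (Homo sapiens) for cytotoxicity, read by MTT assay, with a stated time of 2 days, tested at 10 uM (on this read-out higher numbers stand for more inhibition at the one concentration tested (going by the name of the read-out) and lower numbers for less inhibition), compound 2 gives 26.6%. Within the data shown here, that is the only number measured here, since for compound 1 the outcome is "not determined" (no result reported), so compound 2 cannot be placed against any neighbour. Compound 3, `CCN(CC)CCNc1nc(NCc2ccco2)c2ccccc2n1`, has not yet been measured in this assay. It differs from compound 2 in one place only: hydrogen in place of fluoro on an aromatic carbon. Among the measured compounds shown here, no pair of measured compounds shows what such a change does, so there is no measured step to lean on. The expected step is small, a number 1.6 percentage points lower from compound 2 to compound 3 (within the scatter), within the usual scatter. Compound 3 is therefore estimated to give about 25% in this assay, with a range from 10% to 40%.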

Compound 3, a percentage reported as inhibition, at one concentration (the size of the read-out at that concentration, not a potency): 28.5%
The estimate for compound 3 lay 3.5 percentage points below the measured number, within the range that was stated.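

In this assay, among these compounds, hydrogen in place of fluoro on this aromatic carbon gives a number 1.9 percentage points higher from compound 2 to compound 3 (within the scatter) and so gives the first measured look at this position. The fluoro group is therefore not needed to keep inhibition at this level, and this one swap gives no sign that the read-out depends on which of these two atoms sits there. Nothing measured here explains this result.

From the compounds shown here alone, whether a chloro, methoxy or amino group at the same place would also leave the read-out unchanged remains open, as does the effect of a longer chain on the side that carries the diethylamino group. Going by these compounds, each number also comes from one concentration, so the potency of compound 2 and compound 3 remains unknown.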